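Alpha-1 binding in an arylpiperazine series: methoxy against chloro

The compounds below may be only part of what the source reports. "The series", "measured", "known", "first", "only" and "open" are said of these compounds alone.

Measured so far, in an assay on cell membranes from brain for binding affinity to Adrenergic receptor alpha-1 (Rattus norvegicus), read by radioligand binding; a lower number here means a stronger inhibitor, a higher number a weaker inhibitor:
compound 1, `COc1ccccc1N1CCN(CCCCn2nc(-n3cnc4ccccc43)ccc2=O)CC1`, gives 1.1 nM
compound 2, `O=c1ccc(-n2cnc3ccccc32)nn1CCCCN1CCN(c2ccccc2Cl)CC1`, gives 1.3 nM
compound 3, `COc1ccccc1N1CCN(CCn2nc(-n3ccnc3)ccc2=O)CC1`, gives 237 nM

Compounds 1 and 2 share a core and differ in one place, (chloro in place of methoxy on an aromatic carbon). The step of a 1.2-fold higher number from compound 1 to compound 2 (0.07 log units; within the scatter) is small, so in this assay the two sit together and no order between them is claimed.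

Compound 3 carries a different core; the difference between the core of compound 1 and the core of compound 3 is not broken down here. Whatever that difference does, in this assay compound 3 stands far from both, its value being the highest of the three numbers, and the gap to compound 2 as well as to compound 1 lies beyond the scatter.

Compound 4, `O=c1ccc(-n2ccnc2)nn1CCN1CCN(c2ccccc2Cl)CC1`, is not yet measured. It differs from compound 3 by chloro in place of methoxy on an aromatic carbon, which is the same change as that from compound 1 to compound 2, at the same place. Since a 1.2-fold higher number from compound 1 to compound 2 (0.07 log units; within the scatter) was within the scatter, the step from compound 3 to compound 4 is expected to be of about the same size, a 1.2-fold higher number from compound 3 to compound 4 (0.07 log units; within the scatter), resting on that single earlier pair and on nothing else. Accordingly compound 4 is expected to give about 280 nM in this assay, estimated between 120 nM and 650 nM.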

Compound 4, inhibition constant: 472 nM
Beside the measured number, compound 4's estimate is 1.7-fold (0.23 log units) below it; the measured number falls inside the stated range.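

In this assay, the change from 2-methoxyphenyl to 2-chlorophenyl on the second core gives a 2.0-fold higher number from compound 3 to compound 4 (0.30 log units; within the scatter), so no order is claimed between these two compounds. Set beside the first pair, the two steps show no difference: the same change on two cores in this assay, a 1.2-fold higher number (0.07 log units; within the scatter) from compound 1 to compound 2 and a 2.0-fold higher number (0.30 log units; within the scatter) from compound 3 to compound 4, 1.7-fold (0.23 log units) apart, within the scatter of two such steps The change therefore carries across these two cores as a step within the scatter, whether the values lie near the low end of the series or far up it, but two pairs do not show that it would hold on any other core, and they say nothing about why the two groups read alike.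

Still open is how other groups at this place on the ring, such as fluoro, methyl or trifluoromethyl, would read in this assay, since only methoxy and chloro appear there in the compounds shown. Also open is which part of the difference between the core of compound 1 and the core of compound 3 carries the gap between their values, as no pair shown changes the linking chain alone, for instance a longer chain on the core of compound 3.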